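The source may hold more compounds than are shown below. What is called first, only, known or untested is meant among the compounds shown, and "the series" means these compounds.

Of the compounds shown here, three built on the same core have been tested in a functional assay on DU-145 cells (Homo sapiens) for cytotoxicity, read by MTT assay, with a stated time of 48 h; on this read-out lower numbers stand for stronger inhibition and higher numbers for weaker inhibition. Compound 1 `Cc1ccc(S(=O)(=O)/N=C(/CCNC2=CC(=O)c3ccccc3C2=O)Nc2ccc(F)cc2)cc1` gives 12200 nM. Compound 2 `Cc1ccc(S(=O)(=O)/N=C(/CCNC2=CC(=O)c3ccccc3C2=O)Nc2cc(F)c(F)c(F)c2)cc1` gives 12600 nM, and the step of a 1.0-fold higher number from compound 1 to compound 2 (0.01 log units; within the scatter) separates the two. Compound 3 `Cc1ccc(S(=O)(=O)/N=C(/CCNC2=CC(=O)c3ccccc3C2=O)NC(C)C)cc1` gives 28500 nM, the highest of the three numbers and therefore the weakest inhibitor among them, since its steps to both others lie beyond the scatter: a 2.3-fold higher number from compound 1 to compound 3 (0.37 log units; beyond the scatter) and a 2.3-fold higher number from compound 2 to compound 3 (0.35 log units; beyond the scatter).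

Compound 4 `Cc1ccc(S(=O)(=O)/N=C(\N)CCNC2=CC(=O)c3ccccc3C2=O)cc1` has not yet been measured. It differs from compound 3 by hydrogen in place of isopropyl on an amine nitrogen. Among the measured compounds shown here, no measured step takes the group on this nitrogen away altogether, so the only guidance comes from the two steps that end at compound 3, a 2.3-fold higher number from compound 1 to compound 3 (0.37 log units; beyond the scatter) and a 2.3-fold higher number from compound 2 to compound 3 (0.35 log units; beyond the scatter), both of which show that exchanging an aromatic ring for isopropyl raised the number modestly. Removing the isopropyl as well moves further away from the aromatic ring, so a modest further rise, or a step that stays within the scatter, is expected rather than a gain. The estimate for compound 4 in this assay is 38000 nM, with a range from 15000 nM to 95000 nM, which corresponds to an expected step of a 1.3-fold higher number from compound 3 to compound 4 (0.12 log units; within the scatter).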

Compound 4, half-maximal inhibitory concentration: 30900 nM
For compound 4 the middle estimate is 1.2-fold (0.09 log units) above the measured one, and the stated range covers the measured number.
By their numbers in this assay, from the lowest: compounds 1 and 2 (each within the scatter of the next); then compounds 3 and 4 (each within the scatter of the next).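

In this assay, going from isopropylamino to amino gives a 1.1-fold higher number from compound 3 to compound 4 (0.04 log units; within the scatter), so the two compounds cannot be told apart and the isopropyl group shows no measurable contribution on this nitrogen compared with a bare hydrogen. The comparisons with the aromatic compounds are different, with a 2.5-fold higher number from compound 2 to compound 4 (0.39 log units; beyond the scatter) and a 2.5-fold higher number from compound 1 to compound 4 (0.40 log units; beyond the scatter), both beyond the scatter; among these four compounds, the two carrying a fluorinated phenyl ring on this nitrogen have the lower numbers, and neither the hydrogen nor the isopropyl compound goes against that split. No measurement is available here that explains this difference between the two pairs.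

The compounds shown leave open whether the fluorine atoms matter at all, since a plain phenyl ring, a benzyl group or a saturated cyclohexyl ring on this nitrogen could fall with either pair. As far as these compounds go, it also remains open whether a longer alkyl chain would stay level with compound 3 and compound 4 or move towards compound 1 and compound 2.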